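Dichlorophenyl for methoxyphenyl on the shared core

A few compounds are considered here, and "the series" means these few. Any claim that something is new, unique, unknown or untested is made for them only; others in the source may bear on it.

Three compounds share one core and differ only at a single aromatic carbon. Compound 1 `CC(=O)c1cc2ccc(OCCCn3cc(CNC(=O)CCCCC4CCSS4)nn3)cc2oc1=O` carries an acetyl group there, compound 2 `O=C(CCCCC1CCSS1)NCc1cn(CCCOc2ccc3cc(C(=O)O)c(=O)oc3c2)nn1` a carboxy group, and compound 3 `COc1ccc(-c2cc3ccc(OCCCn4cc(CNC(=O)CCCCC5CCSS5)nn4)cc3oc2=O)cc1` a 4-methoxyphenyl group. In a functional assay on PC-12 cells (Rattus norvegicus) for cytotoxicity, read by MTT assay, with stated times of 3 h and 2 h, tested at 1 uM (on this read-out higher numbers stand for a stronger effect at the one concentration tested and lower numbers for a weaker effect), compound 1 gives 35.5%, compound 2 gives 52.1%, and compound 3 gives 47.4%. Compound 3 thus stands second highest of the three: its gap to compound 2 lies within the scatter, whereas the step of a number 11.9 percentage points higher from compound 1 to compound 3 (beyond the scatter) is beyond it. The step of a number 16.6 percentage points higher from compound 1 to compound 2 (beyond the scatter) is likewise beyond the scatter, and the step of a number 4.7 percentage points lower from compound 2 to compound 3 (within the scatter) is within it.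

Compound 4 `O=C(CCCCC1CCSS1)NCc1cn(CCCOc2ccc3cc(-c4ccc(Cl)c(Cl)c4)c(=O)oc3c2)nn1` differs from compound 3 by one change: 3,4-dichlorophenyl in place of 4-methoxyphenyl on an aromatic carbon. Within the data shown here, no measured step exchanges one phenyl ring for another. The steps of a number 11.9 percentage points higher from compound 1 to compound 3 (beyond the scatter) and a number 4.7 percentage points lower from compound 2 to compound 3 (within the scatter) touch the same aromatic carbon, but they replace acetyl or carboxy, and all three measured numbers sit within a modest band. The expectation is therefore a step of a number 0.4 percentage points lower from compound 3 to compound 4 (within the scatter), nothing beyond the scatter in this assay. For compound 4 the estimated value in this assay is 47%, with a range from 32% to 62%.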

Compound 4, a percentage reported as activity, at one concentration (the size of the read-out at that concentration, not a potency): 42.4%
The estimate for compound 4 lay 4.6 percentage points above the measured number; the range from low to high includes it.
By their numbers in this assay, from the lowest: compounds 1, 4, 3 and 2 (each within the scatter of the next, the first and the last beyond it).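

In this assay, among these compounds, the first exchange of one phenyl ring for another at this aromatic carbon, a number 5 percentage points lower from compound 3 to compound 4 (within the scatter), stays within the scatter, even though the entering 3,4-dichlorophenyl carries chlorine and lacks the hydrogen-bond acceptor of the leaving 4-methoxyphenyl. Compound 4 also cannot be separated from either non-aryl compound, since a number 9.7 percentage points lower from compound 2 to compound 4 (within the scatter) and a number 6.9 percentage points higher from compound 1 to compound 4 (within the scatter) both lie within the scatter, whereas a number 11.9 percentage points higher from compound 1 to compound 3 (beyond the scatter) does not, so the two aryl compounds differ in whether they stand clear of the acetyl compound but cannot be told apart from each other. No measurement offered here explains these numbers or ties them to any property of the rings.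

The compounds shown leave open whether an unsubstituted phenyl, a pyridine ring, an amine or a longer chain at this aromatic carbon would stand beyond the scatter from compound 3. They also leave open whether the closeness of compound 3 and compound 4 would hold at other concentrations, as each compound is described here at only one.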